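Cytotoxicity of a third hydroxyphenyl compound

The source may report more compounds than this note shows. Statements on the series, on what has been measured and on what is new or still open speak of the compounds shown alone.

In an ADME assay on NIH3T3 cells (Mus musculus) for cytotoxicity, read by MTT assay, with a stated time of 24 h (on this read-out lower numbers stand for stronger inhibition and higher numbers for weaker inhibition), compound 1 (`Oc1cccc(/C=N/n2c(S)nnc2-c2cnccn2)c1`) gives 151000 nM and compound 2 (`Oc1ccccc1/C=N/n1c(S)nnc1-c1cnccn1`) gives 131000 nM under the same conditions. Among the measured compounds shown here, these two numbers lie within the usual scatter of each other, so compound 2 cannot be separated from the only other compound measured. Compound 3 (`Oc1ccc(/C=N/n2c(S)nnc2-c2cnccn2)cc1`) carries 4-hydroxyphenyl in place of 2-hydroxyphenyl on a carbon with a double bond to nitrogen. For the measured compounds named here, one measured step bears on this change, at the same place: a 1.2-fold lower number from compound 1 to compound 2 (0.06 log units; within the scatter) for 2-hydroxyphenyl in place of 3-hydroxyphenyl. Going by the values given here, with only that small step as evidence, no shift beyond the scatter is expected in this assay and no direction is favoured. The estimate is an expected 1.1-fold higher number from compound 2 to compound 3 (0.03 log units; within the scatter) and no more than that. Compound 3 is expected to give 140000 nM (estimated range 75000 nM to 260000 nM).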

Compound 3, half-maximal inhibitory concentration: 175000 nM
Beside the measured number, compound 3's estimate is 1.3-fold (0.10 log units) below it; measured number inside the range.
By their numbers in this assay, from the lowest: compounds 2, 1 and 3 (each within the scatter of the next).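

In this assay, the 4-hydroxyphenyl group completes the series of three hydroxyphenyl groups on the carbon with a double bond to nitrogen, with a 1.3-fold higher number from compound 2 to compound 3 (0.13 log units; within the scatter) and a 1.2-fold higher number from compound 1 to compound 3 (0.06 log units; within the scatter) both lying within the scatter. Where the earlier pair could speak only for the 2-hydroxyphenyl and 3-hydroxyphenyl groups, all three compounds now stand within the scatter of one another, so this assay does not separate them by where the hydroxyl group sits on the phenyl ring. No measurement is available that would account for these numbers.

The compounds shown leave open whether a different group at this place, such as an amine, a carboxylic acid or a methoxy group on the phenyl ring, would give a step beyond the scatter. They also leave open whether changes elsewhere on the shared core would do so.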